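The source may hold more compounds than are shown below. What is called first, only, known or untested is meant among the compounds shown, and "the series" means these compounds.

Measured compounds and their numbers in a functional assay on HepG2 cells (Homo sapiens) for cytotoxicity, read by MTT assay, with a stated time of 72 h; on this read-out higher numbers stand for weaker inhibition and lower numbers for stronger inhibition:
compound 1 `Cc1cc(=O)n(-c2ccc(F)c(F)c2)nc1C(=O)Nc1ccc(Oc2ncnc3ccsc23)cc1` — compound 1 gives 9230 nM;
compound 2 `Cc1cc(=O)n(-c2ccccc2OC(F)(F)F)nc1C(=O)Nc1ccc(Oc2ncnc3sccc23)cc1` — compound 2 gives 14400 nM;
compound 3 `Cc1cc(=O)n(-c2ccc(F)c(F)c2)nc1C(=O)Nc1ccc(Oc2ncnc3sccc23)cc1` — compound 3 gives 16800 nM.

Compound 3 holds the highest of the three numbers in this assay, yet its numbers sit within the scatter of both neighbours: the step of a 1.8-fold higher number from compound 1 to compound 3 (0.26 log units; within the scatter) and the step of a 1.2-fold higher number from compound 2 to compound 3 (0.07 log units; within the scatter) both stay inside the usual spread of repeats. Nothing among the three measured compounds separates them beyond the scatter.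

Compound 4 `Cc1cc(=O)n(-c2ccc(F)c(F)c2)nc1C(=O)Nc1ccc(Oc2ncnc3sccc23)c(F)c1` arises from compound 3 by fluoro in place of hydrogen on an aromatic carbon. Among the measured compounds shown here, no measured step touches this ring or this kind of exchange; the two steps that are known, the swap of the bicyclic group on the oxygen and the swap of the group on the aromatic nitrogen, each moved the number only within the scatter. On that basis compound 4 is expected to show a step of a 1.1-fold lower number from compound 3 to compound 4 (0.05 log units; within the scatter) in this assay, which is no change beyond the scatter. Compound 4 is therefore estimated at 15000 nM, with a range from 6000 nM to 40000 nM.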

Compound 4, half-maximal inhibitory concentration: > 40000 nM
Compound 4: no number, only a limit; the forecaster's own chance of this, stated with the estimate: 15%; middle value at least 2.6-fold (0.42 log units) from the limit.
By their numbers in this assay, from the lowest: compounds 1, 2 and 3 (each within the scatter of the next). At a limit, above all of these: compound 4.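

In this assay, fluoro in place of hydrogen on an aromatic carbon of the six-membered aromatic ring of carbon only gives an at least 2.3-fold higher number from compound 3 to compound 4 (0.37 log units; beyond the scatter), the first step among these compounds that lies beyond the scatter. The exchanges on the oxygen and on the aromatic nitrogen stayed within the scatter, so this place, ortho to a large group and meta to a large group, is the only one shown where a change moves the number beyond it, and that change adds a single heavy atom. Compound 4 gives only a limit of the assay, not a number: the limit of > 40000 nM in this assay, at which 1 of the 4 values shown sits.

Going by these compounds, whether the step belongs to fluoro in particular remains open; chloro, methyl or methoxy on the same carbon would address that. On these data alone, it is also open whether fluoro at this place acts the same way alongside the 2-(trifluoromethoxy)phenyl group of compound 2.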